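The source may hold more compounds than are shown below. What is called first, only, known or untested is meant among the compounds shown, and "the series" means these compounds.

Of the compounds shown here, three on a shared core have been measured in an assay on isolated protein for inhibition of DNA topoisomerase 1 (Homo sapiens), with a stated time of 30 min, tested at 20 uM; on this read-out lower numbers stand for a weaker effect and higher numbers for a stronger effect at the one concentration tested. Compound 1, `Cc1ccc2c(=O)[nH]c(-c3ccccc3OC(F)(F)F)nc2c1`, gives 100%. Compound 2, `Cc1ccc2c(=O)[nH]c(-c3ccccc3F)nc2c1`, gives 0% in this assay. Compound 3, `Cc1ccc2nc(-c3cccc(F)c3)[nH]c(=O)c2c1`, gives 0.2% in this assay. Within the data shown here, the one recorded step is a number 100 percentage points higher from compound 2 to compound 1 (beyond the scatter), with the change (trifluoromethoxy in place of fluoro on an aromatic carbon). The difference between the core of compound 2 and the core of compound 3 is not broken down here. Compound 3 and compound 2 give numbers within the scatter of each other, while compound 1 stands beyond the scatter above both.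

Compound 4, `Cc1ccc2nc(-c3cccc(OC(F)(F)F)c3)[nH]c(=O)c2c1`, is not yet measured. It differs from compound 3 by trifluoromethoxy in place of fluoro on an aromatic carbon, the same kind of change as that from compound 2 to compound 1, occurring twice among these compounds, but at a different place: in compound 1 the entering group sits ortho to a large group, in compound 4 meta to a large group. Among the measured compounds shown here, the expectation for compound 4 in this assay rests on the single step of a number 100 percentage points higher from compound 2 to compound 1 (beyond the scatter); the place differs, so the step is taken as less certain to repeat in full. Compound 4 is expected to give 55%, estimated between 10% and 95%. The expected step is a number 54.8 percentage points higher from compound 3 to compound 4 (beyond the scatter).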

Compound 4, a percentage reported as inhibition, at one concentration (the size of the read-out at that concentration, not a potency): 0%
Compound 4: middle estimate off by 55 percentage points, on the high side; the whole stated range lies above it.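

In this assay, trifluoromethoxy in place of fluoro on an aromatic carbon comes with a number 0.2 percentage points lower from compound 3 to compound 4 (within the scatter). Set beside the earlier step, the same change does not carry over from one core to the other in this series: the same change on two cores in this assay, a number 100 percentage points higher (beyond the scatter) from compound 2 to compound 1 and a number 0.2 percentage points lower (within the scatter) from compound 3 to compound 4, 100.2 percentage points apart, beyond the scatter of two such steps The two steps differ both in the core and in the place of the entering group, which sits meta to a large group in compound 4, and these compounds do not show which of the two differences accounts for the gap.

Open, going by these compounds, is whether compound 1, at 100% in this assay, owes its value to trifluoromethoxy at its own place, to its own core, or to the two together, which a single compound carrying that group at the same place on the core of compound 3 would help to separate. Also open, on these data alone, is how other groups on the same aromatic ring, such as an amine, a carboxylic acid or a longer alkoxy chain, would read out on either core.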